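The source may hold more compounds than are shown below. What is called first, only, known or untested is meant among the compounds shown, and "the series" means these compounds.

Measured in a functional assay on A549 cells (Homo sapiens) for cytotoxicity, read by MTT assay, with a stated time of 72 h (on this read-out higher numbers stand for weaker inhibition and lower numbers for stronger inhibition), so far:
- compound 1 `CNC(=O)c1cc(Oc2ccc(C3=NNC(c4cccc([N+](=O)[O-])c4)C3)cc2)ccn1` gives "not determined" (no result reported)
- compound 2 `CNC(=O)c1cc(Oc2ccc(C3=NNC(c4ccccc4)C3)cc2)ccn1` gives 8600 nM

Among the compounds with values here, compound 1 therefore stands without a number, and the only reading near it is that of compound 2 at 8600 nM. Compound 3 `CNC(=O)c1cc(Oc2ccc(C3=NN(C(N)=S)C(c4cccc([N+](=O)[O-])c4)C3)cc2)ccn1` differs from compound 1 by a group of 3 heavy atoms (1 carbon, 1 nitrogen, 1 sulfur; no ring) in place of a hydrogen atom, on an amine nitrogen in a ring, sitting on an amine nitrogen in a ring. Within the data shown here, no measured step covers this change, so the expectation is loose: a moderate step towards stronger inhibition in this assay, only slightly beyond the scatter, taking compound 2 as the reference. For compound 3 the estimated value is 3000 nM, with an expected range of 700 nM to 12000 nM.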

Compound 3, half-maximal inhibitory concentration: > 50000 nM
Compound 3 ended at the assay's limit; the forecaster's own chance of this, stated with the estimate: 10%; middle value at least 16-fold (1.22 log units) away from the limit.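

No step can be read between compound 1 and compound 3. In this assay compound 3 gives > 50000 nM, which is a limit and not a number. Going by these compounds, the size of the change from the added group of 3 heavy atoms, with the 3-nitrophenyl group in place, stays open.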